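The source may hold more compounds than are shown below. What is called first, only, known or untested is meant among the compounds shown, and "the series" means these compounds.

Measured so far in a physicochemical assay for solubility, read by HPLC, in simulated intestinal fluid, with a stated time of 16 h, tested at 125 ug/mL; on this read-out lower numbers stand for lower solubility and higher numbers for higher solubility:
compound 1, `CNC(=O)c1cc(C(=O)NC2CC2)c(C)n(Cc2ccccc2)c1=O` — 577 ug/mL
compound 2, `CNC(=O)c1cc(C(=O)NC2CCC2)cn(Cc2cccnc2)c1=O` — 189 ug/mL
compound 3, `CNC(=O)c1cc(C(=O)NC2CC2)cn(Cc2cccc3[nH]ccc23)c1=O` — 17 ug/mL

Compound 3 stands lowest of the three numbers in this assay. Its nearest neighbour is compound 2, whose value lies well beyond the scatter above it, and compound 1 sits further off still, also beyond the scatter. No two of these compounds differ in a single place, so no isolated step is set out between them; the three are separated by several changes at once and the numbers can only be read as they stand.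

Compound 4, `CNC(=O)c1cc(C(=O)NC2CC2)cn(Cc2cccc3occc23)c1=O`, is the next entry for this assay. It differs from compound 3 by 1-benzofuran-4-yl in place of 1H-indol-4-yl on a saturated chain carbon bound to an aromatic nitrogen. The measured set contains nothing that isolates this change, so the expectation rests on compound 3 alone. The step expected from this change is small, downward if anything, a 1.4-fold lower number from compound 3 to compound 4 (0.15 log units; within the scatter), and could sit within the scatter. Because compound 3 gives 17 ug/mL, the value expected for compound 4 in this assay is 12 ug/mL, with a range from 4 ug/mL to 35 ug/mL.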

Compound 4, solubility: 74 ug/mL
The estimate for compound 4 lay 6.2-fold (0.79 log units) below the measured number; the whole stated range lies below it.
By their numbers in this assay, from the lowest: compound 3; then compound 4; then compound 2; then compound 1.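

In this assay, among the compounds shown here, the change to 1-benzofuran-4-yl in place of 1H-indol-4-yl on a saturated chain carbon bound to an aromatic nitrogen gives a 4.4-fold higher number from compound 3 to compound 4 (0.64 log units; beyond the scatter) and is the first single-place step, so this position can now be read directly rather than through compounds that differ in several places at once. The two groups have the same heavy-atom count and the same ring make-up, and they differ in the hetero atom and in the hydrogen-bond donor and acceptor counts, so the read-out here is not set by ring type or heavy-atom count alone. No supporting data bear on why the number moves.

The compounds shown leave open whether the step follows the loss of the indole hydrogen on nitrogen or the entry of the oxygen, and a 1-methyl-1H-indol-4-yl or a 1-benzothiophen-4-yl group on the same chain carbon would separate the two. Also open, going by these compounds, is whether this change gives a step of similar size with the cyclobutyl amide of compound 2 or on the methyl-bearing core of compound 1.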